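A Bromine Swap in a Weak Growth Inhibitor Series

The compounds below may be only part of what the source reports. "The series", "measured", "known", "first", "only" and "open" are said of these compounds alone.

In a functional assay on HCT-15 cells (Homo sapiens) for inhibition, read by sulforhodamine B assay (a higher number here means a weaker inhibitor of growth, a lower number a stronger inhibitor of growth), compound 1 `O=C(CCC1=CCCN(Cc2ccc(F)cc2)C1=O)NO` gives 9960 nM. Compound 2 `COc1ccc(CN2CCC=C(CCC(=O)NO)C2=O)cc1` gives 6890 nM. The change between them is a 1.4-fold lower number from compound 1 to compound 2 (0.16 log units; within the scatter).

Compound 3 `Cc1ccccc1CN1CCC=C(CCC(=O)NO)C1=O` reads > 10000 nM, which is a limit of the assay and not a number. Its exact place is therefore unknown, and the step to it is a number no lower from compound 1 to compound 3 (the limit leaves the size open).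

Compound 4 `O=C(CCC1=CCCN(Cc2ccc(Br)cc2)C1=O)NO` has not been measured yet. The difference is 4-bromophenyl in place of 2-methylphenyl on a saturated chain carbon bound to an amide-type nitrogen in a ring.

The closest measured match is compound 1 with its 4-fluorophenyl, and the swap in a 1.4-fold lower number from compound 1 to compound 2 (0.16 log units; within the scatter) did not move the number beyond the scatter. Compound 4 is therefore expected to sit close to compound 1 at 9960 nM. Compound 4 could itself reach the limit of the assay. Going by these compounds, the expected change is an at least 1.3-fold lower number from compound 3 to compound 4 (0.12 log units; that floor lies within the scatter), though the true size stays open. For compound 4 the estimate is 7500 nM, with an expected range of 4000 nM to 13000 nM.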

Compound 4, concentration for 50% growth inhibition: 1720 nM
Compound 4: the middle estimate sits 4.4-fold (0.64 log units) above what was measured, and the stated range ends above it.
By their numbers in this assay, from the lowest: compound 4; then compounds 2 and 1 (each within the scatter of the next). At a limit, above all of these: compound 3.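

In this assay, going by these compounds alone, bromo is the first group on this aromatic carbon to move the number beyond the scatter, with a 5.8-fold lower number from compound 1 to compound 4 (0.76 log units; beyond the scatter) for bromo in place of fluoro and a 4.0-fold lower number from compound 2 to compound 4 (0.60 log units; beyond the scatter) for bromo in place of methoxy. The group carried here can therefore change growth inhibition, something the fluoro and methoxy compounds alone gave no sign of. Putting 4-bromophenyl in place of 2-methylphenyl gives an at least 5.8-fold lower number from compound 3 to compound 4 (0.76 log units; beyond the scatter), and that size is only a floor, since its starting value is a limit of the assay: the limit of > 10000 nM in this assay, at which 1 of the 4 values shown sits.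

The compounds shown leave open whether chloro, iodo or trifluoromethyl on the same aromatic carbon would give a similar drop. They also do not show how 2-bromophenyl would compare with 4-bromophenyl.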